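Side-chain swap from compound 2 to compound 3

The source may hold more compounds than are shown below. What is called first, only, known or untested is meant among the compounds shown, and "the series" means these compounds.

Compound 1 `CN(C)CCn1c(N)c(-c2nc3ccccc3n2C)c2nc(C#N)c(C#N)nc21`: > 50000 nM, a limit
Compound 2 `CCN(CC)CCCn1c(N)c(-c2nc3ccccc3n2C)c2nc(C#N)c(C#N)nc21`: 2810 nM

For the measured compounds named here, in a functional assay on HL-60 cells (Homo sapiens) for antiproliferative activity, read by MTT assay, with a stated time of 48 h (on this read-out lower numbers stand for stronger inhibition and higher numbers for weaker inhibition), compound 2 gives the only actual number, 2810 nM. Compound 1 stands at a limit, (the limit of > 50000 nM in this assay, at which 1 of the 2 values shown sits). Compound 3 `CN(C)CCCCn1c(N)c(-c2nc3ccccc3n2C)c2nc(C#N)c(C#N)nc21` differs from compound 2 by (dimethylamino)methyl in place of diethylamino on a saturated chain carbon, three bonds along the chain from an aromatic nitrogen. Going by the values given here, the one measured step bearing on this is large: an at least 17-fold lower number from compound 1 to compound 2 (1.25 log units; beyond the scatter). That step brought in the diethylamino end, and compound 3 returns to a dimethylamino end on a longer chain, so a modest rise in the number is expected in this assay. For compound 3 the estimated value is 6000 nM, with an expected range of 1800 nM to 30000 nM. This estimate means an expected 2.1-fold higher number from compound 2 to compound 3 (0.33 log units; beyond the scatter).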

Compound 3, half-maximal inhibitory concentration: 740 nM
Compound 3: middle estimate off by 8.1-fold (0.91 log units), on the high side, outside the stated range (below it).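

At this position on the chain, the 4-(dimethylamino)butyl group in place of the 3-(diethylamino)propyl group gives a 3.8-fold lower number from compound 2 to compound 3 (0.58 log units; beyond the scatter) in this assay, so a dimethylamino end does not rule out the better numbers in this set. With the dimethylamino end kept and the chain extended, the change gives an at least 67-fold lower number from compound 1 to compound 3 (1.82 log units; beyond the scatter). The value at the compound 1 end of that step is a limit, not a number: the limit of > 50000 nM in this assay, at which 1 of the 3 values shown sits.

Chain length and amine end change together between compound 2 and compound 3, so their separate contributions remain unresolved. Open questions are how a 4-(diethylamino)butyl chain, a longer chain, or a cyclic amine such as morpholine would behave.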